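This account rests on a few compounds, and the source may have more. Where it says the series, first, only, none or still open, it means among the compounds named here.

Of the compounds shown here, three have numbers so far in a functional assay on NALM-6 cells (Homo sapiens) for cytotoxicity, read by luminescence and CellTiter-Glo, with a stated time of 3 days (on this read-out lower numbers stand for stronger inhibition and higher numbers for weaker inhibition), and all of them lie close together. Compound 1 (`N#Cc1ccc(NC(=O)c2ccc(Br)cc2O)cc1Cl`) gives 920 nM and compound 2 (`O=C(Nc1ccc(C(F)(F)F)cc1)c1cc(Cl)c(-c2ccccc2)cc1O`) gives 800 nM on this read-out. Compound 3 (`O=C(Nc1ccc(C(F)(F)F)cc1)c1cc(Br)c(F)cc1O`) stands at 1300 nM and that number lies within the usual scatter of both others, so the three cannot be ranked.

The next compound is compound 4 (`O=C(Nc1ccc(C(F)(F)F)cc1)c1cc(Br)c(-c2ccccc2)cc1O`), which differs from compound 3 in one place (phenyl in place of fluoro on an aromatic carbon). Phenyl takes the place of fluoro on an aromatic carbon, ortho to a bromo group and meta to a hydroxy group. For the measured compounds named here, no measured pair that differs in one place is available, so this step has no direct precedent in the data. The nearest guide is compound 2, which also carries a phenyl group and gives 800 nM in this assay without leaving the scatter around compound 3. A small move toward a lower number is therefore expected, and none beyond the scatter. The estimated change (a 1.7-fold lower number from compound 3 to compound 4 (0.24 log units; within the scatter)) stays inside that scatter. For compound 4 the estimated value is 750 nM with an expected range from 280 nM to 2000 nM on this read-out.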

Compound 4, half-maximal inhibitory concentration: 1000 nM
Compound 4: middle estimate off by 1.3-fold (0.12 log units), on the low side, and the stated range covers the measured number.
By their numbers in this assay, from the lowest: compounds 2, 1, 4 and 3 (each within the scatter of the next).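

In this assay, phenyl in place of fluoro on an aromatic carbon, ortho to a bromo group and meta to a hydroxy group, gives a 1.3-fold lower number from compound 3 to compound 4 (0.11 log units; within the scatter) and so brings no readable change, although six heavy atoms and a whole aromatic ring enter where a single fluorine left. For the compounds shown here, this is the first direct comparison at this position, and it shows that, for these two groups, the number stays within the scatter whatever the difference in size. The second comparison, bromo in place of chloro on an aromatic carbon with the phenyl group kept, gives a 1.3-fold higher number from compound 2 to compound 4 (0.10 log units; within the scatter) and likewise separates nothing, while no evidence is available to account for either result.

The compounds shown leave open whether any group at the position that holds fluoro or phenyl can move the number beyond the scatter, for instance an amine, a carboxylic acid or a longer chain. They also leave open whether the hydroxy group on the shared core matters in this assay, since all four compounds carry it and a methoxy group in its place would be needed to tell.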